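The source may report more compounds than this note shows. Statements on the series, on what has been measured and on what is new or still open speak of the compounds shown alone.

Compound 1 `Nc1cc(Cc2ccn(Cc3cccc(Oc4ccccc4)c3)n2)c2nn[nH]c2n1` gives 1100 nM in an assay on cells for inhibition of thyroid peroxidase (Homo sapiens), with stated times of 10 min and 15 min; a higher number here means a weaker inhibitor, a lower number a stronger inhibitor.
Compound 2 `Nc1cc(Cc2ccn(Cc3cccc(Cc4ccccc4)c3)n2)c2nn[nH]c2n1` gives 1900 nM in this assay.
Compound 3 `Nc1cc(Cc2ccn(Cc3ccccc3)n2)c2nn[nH]c2n1` gives 2300 nM in this assay.

Among the measured compounds shown here, compound 3 has the highest number of the three, though its gap to compound 2 lies within the scatter; only the step of a 2.1-fold higher number from compound 1 to compound 3 (0.32 log units; beyond the scatter) is beyond it. Compound 4 `Nc1cc(Cc2ccn(Cc3cccc(C4CCNCC4)c3)n2)c2nn[nH]c2n1` differs from compound 3 by piperidin-4-yl in place of hydrogen on an aromatic carbon. For the measured compounds named here, the steps that bear on this change are a 2.1-fold higher number from compound 1 to compound 3 (0.32 log units; beyond the scatter) and a 1.2-fold higher number from compound 2 to compound 3 (0.08 log units; within the scatter), since both also swap a group for hydrogen at that same aromatic carbon; one was modest, the other within the scatter. A step of similar small size is therefore expected in this assay, if anything toward a lower number. Compound 4 is expected to give about 1700 nM, between 600 nM and 4500 nM, a step of a 1.4-fold lower number from compound 3 to compound 4 (0.13 log units; within the scatter).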

Compound 4, half-maximal inhibitory concentration: 21000 nM
The estimate for compound 4 lay 12-fold (1.09 log units) below the measured number; measured number outside the range, above it.
By their numbers in this assay, from the lowest: compounds 1, 2 and 3 (each within the scatter of the next, the first and the last beyond it); then compound 4.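

In this assay piperidin-4-yl brings a 9.1-fold higher number from compound 3 to compound 4 (0.96 log units; beyond the scatter) and so shows that this aromatic carbon is not indifferent to what sits on it, since benzyl and phenoxy stayed much closer to hydrogen. Against those two groups it brings an 11-fold higher number from compound 2 to compound 4 (1.04 log units; beyond the scatter) and a 19-fold higher number from compound 1 to compound 4 (1.28 log units; beyond the scatter) as the cost of the swap. Nothing measured here accounts for this weakening.

The compounds shown leave open whether the loss belongs to the ring or to its nitrogen. A cyclohexyl group on this carbon, the same ring with carbon in place of that nitrogen, would separate the two.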